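This account rests on a few compounds, and the source may have more. Where it says the series, first, only, none or still open, it means among the compounds named here.

Three compounds have been measured in a functional assay on A549 cells (Homo sapiens) for cytotoxicity, read by MTT assay, with a stated time of 72 h; on this read-out higher numbers stand for weaker inhibition and lower numbers for stronger inhibition:

- compound 1, `COc1cc(OC)c(OC)cc1/C=C/C(=O)c1ccccc1F`: 79 nM
- compound 2, `COc1ccc(OC)c(/C=C/C(=O)c2ccccc2F)c1`: 114 nM
- compound 3, `COc1ccc(C(=O)/C=C/c2ccc(OC)c(OC)c2OC)c(F)c1`: 108 nM

Compound 1 and compound 2 differ in one place, (hydrogen in place of methoxy on an aromatic carbon). On this change the number moved a 1.4-fold higher number from compound 1 to compound 2 (0.16 log units; within the scatter), so the two sit together within the usual scatter of such measurements.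

Compound 3 shares no single counted difference with compound 1; the difference between the two cores is not broken down here. Compound 4, `COc1ccc(C(=O)/C=C/c2ccc(OC)cc2OC)c(F)c1`, is related to compound 3 by hydrogen in place of methoxy on an aromatic carbon. Among the compounds with values here, this is the same kind of change as the one from compound 1 to compound 2, though not the same: in compound 1 the methoxy that leaves sits ortho to a methoxy group, meta to a methoxy group and para to a large group, whereas in compound 3 it sits ortho to two methoxy groups and meta to a large group.

Within the data shown here, the only measured example of this kind of change, from compound 1 to compound 2, stayed within the scatter. Resting on that, the step from compound 3 to compound 4 in this assay is expected to be small, a 1.3-fold higher number from compound 3 to compound 4 (0.11 log units; within the scatter), set beside the earlier one. Compound 4 is therefore estimated at 140 nM, with a likely range from 70 nM to 300 nM.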

Compound 4, half-maximal inhibitory concentration: > 100000 nM
Compound 4: no number, only a limit (the forecaster's own chance of this, stated with the estimate: 5%); middle value at least 710-fold (2.85 log units) away from the limit.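

In this assay compound 4 gives > 100000 nM, which is a limit of the assay and not a number. Replacing with hydrogen the methoxy that sits ortho to two methoxy groups and meta to a large group gives an at least 920-fold higher number from compound 3 to compound 4 (2.96 log units; beyond the scatter), so a change that left the number within the scatter on one core gave a large shift on the other, and its size cannot simply be carried from one core to another in this series: the same change on two cores in this assay, a 1.4-fold higher number (0.16 log units; within the scatter) from compound 1 to compound 2 and an at least 920-fold higher number (2.96 log units; beyond the scatter) from compound 3 to compound 4, at least 640-fold (2.80 log units) apart, beyond the scatter of two such steps These two pairs differ both in the core and in where the methoxy sits, so they do not tell which of the two matters, and two pairs give no general rule for other cores.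

The compounds shown leave open whether another small group in that same place, such as a hydroxy, a fluorine or the longer ethoxy, would keep the number close to that of compound 3, which gives 108 nM. They also leave open whether replacing either of the other two methoxy groups of compound 3 with hydrogen would bring a shift of similar size, or whether this one methoxy stands apart.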